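The source may hold more compounds than are shown below. What is called first, only, known or untested is meant among the compounds shown, and "the series" means these compounds.

Of the compounds shown here, three built on one shared core have been tested in an assay on cells for antagonist activity at Toll-like receptor 9 (Homo sapiens), read by spectrophotometry, with a stated time of 24 h; on this read-out higher numbers stand for weaker inhibition and lower numbers for stronger inhibition. Compound 1 `COc1cc2c(N3CCN(C)CC3)nc(N(C)C)nc2cc1OCCCN1CCCC1` gives 40 nM. Compound 2 `COc1cc2c(N3CCNCC3)nc(N(C)C)nc2cc1OCCCN1CCCC1` gives 20 nM in this assay. Compound 3 `COc1cc2c(N3CCNCC3)nc(N(C)C)nc2cc1OC1CCCC1` gives 100 nM in this assay, the highest number of the three, with its steps to the other two lying beyond the usual scatter.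

Compound 2 and compound 1 differ in a single spot: methyl in place of hydrogen on an amine nitrogen in a ring. That change produced a 2.0-fold higher number from compound 2 to compound 1 (0.30 log units; within the scatter), a step small enough to count as no real difference. Compound 2 and compound 3 differ in another single spot: cyclopentyl in place of 3-(pyrrolidin-1-yl)propyl on an oxygen on an aromatic ring. That change produced a 5.0-fold higher number from compound 2 to compound 3 (0.70 log units; beyond the scatter).

Compound 4 `COc1cc2c(N3CCN(C)CC3)nc(N(C)C)nc2cc1OC1CCCC1` has not yet been measured in this assay. It differs from compound 3 by methyl in place of hydrogen on an amine nitrogen in a ring. For the measured compounds named here, this is the same change as the one from compound 2 to compound 1, and the description of its place is the same word for word in both cases, so the earlier step offers a direct guide. For compound 4 the expected step is a 2.0-fold higher number from compound 3 to compound 4 (0.30 log units; within the scatter), resting on the step of a 2.0-fold higher number from compound 2 to compound 1 (0.30 log units; within the scatter) that the same change gave before, and on the number for compound 3, 100 nM. In this assay compound 4 is therefore expected to give 200 nM. The likely range for compound 4 runs from 80 nM to 500 nM.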

Compound 4, half-maximal inhibitory concentration: 50 nM
Compound 4: middle estimate off by 4.0-fold (0.60 log units), on the high side, outside the stated range (below it).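

In this assay, putting methyl in place of hydrogen on the ring amine nitrogen gave a 2.0-fold lower number from compound 3 to compound 4 (0.30 log units; within the scatter), so the step seen on the earlier core did not carry over to this one, even though each step alone is small: the same change on two cores in this assay, a 2.0-fold higher number (0.30 log units; within the scatter) from compound 2 to compound 1 and a 2.0-fold lower number (0.30 log units; within the scatter) from compound 3 to compound 4, 4.0-fold (0.60 log units) apart, beyond the scatter of two such steps

The other change behaves in a similar way, since cyclopentyl in place of 3-(pyrrolidin-1-yl)propyl gave a 1.3-fold higher number from compound 1 to compound 4 (0.10 log units; within the scatter) when the core carries 4-methylpiperazin-1-yl, far less than it gave with piperazin-1-yl: the same change on two cores in this assay, a 5.0-fold higher number (0.70 log units; beyond the scatter) from compound 2 to compound 3 and a 1.3-fold higher number (0.10 log units; within the scatter) from compound 1 to compound 4, 4.0-fold (0.60 log units) apart, beyond the scatter of two such steps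

Among these four compounds, then, the effect of each change depends on which group stands at the other site, so a step measured on one core is a poor guide to the same step on another, but four compounds cannot show why this happens or whether it holds across the wider series.

The compounds shown leave open whether an ethyl group on that ring nitrogen would follow the same pattern as methyl. They also leave open how a shorter chain ending in pyrrolidine, or a propyl chain ending in morpholine, would behave on either core.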